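Moving the ring nitrogen on the cyclopropyl aryl group

A few compounds are considered here, and "the series" means these few. Any claim that something is new, unique, unknown or untested is made for them only; others in the source may bear on it.

Three compounds have been measured in a functional assay for agonist activity at G protein-coupled receptor 88 (Homo sapiens), read by HTRF and cAMP accumulation; on this read-out lower numbers stand for an effect already at smaller amounts and higher numbers for an effect only at larger amounts of compound:
- compound 1, `CC[C@H](C)[C@H](N)CN(C(=O)[C@@H]1C[C@H]1c1ccc(Cl)cc1)c1ccc(-c2ccccc2)cc1`, gives 4300 nM
- compound 2, `CC[C@H](C)[C@H](N)CN(C(=O)[C@@H]1C[C@H]1c1c(F)cccc1F)c1ccc(-c2ccccc2)cc1`, gives 11000 nM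
- compound 3, `CC[C@H](C)[C@H](N)CN(C(=O)[C@@H]1C[C@H]1c1cccnc1)c1ccc(-c2ccccc2)cc1`, gives 1500 nM

Compound 3 has the lowest number of the three; the steps of a 2.9-fold lower number from compound 1 to compound 3 (0.46 log units; beyond the scatter) and a 7.3-fold lower number from compound 2 to compound 3 (0.87 log units; beyond the scatter) both lie beyond the scatter, so it is the most potent measured so far. Compound 4, `CC[C@H](C)[C@H](N)CN(C(=O)[C@@H]1C[C@H]1c1ccncc1)c1ccc(-c2ccccc2)cc1`, differs from compound 3 by pyridin-4-yl in place of pyridin-3-yl on a saturated ring carbon. Among the compounds with values here, no measured step moves a ring nitrogen; the steps that bear on it, a 2.6-fold higher number from compound 1 to compound 2 (0.41 log units; beyond the scatter) and a 2.9-fold lower number from compound 1 to compound 3 (0.46 log units; beyond the scatter), each exchange the whole aryl group on that saturated ring carbon and were modest. A small step in either direction, or none beyond the scatter, is therefore expected: a 1.3-fold higher number from compound 3 to compound 4 (0.12 log units; within the scatter). Compound 4 is estimated at 2000 nM, between 700 nM and 6000 nM.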

Compound 4, half-maximal effective concentration: 1500 nM
The estimate for compound 4 lay 1.3-fold (0.12 log units) above the measured number; measured number inside the range.
By their numbers in this assay, from the lowest: compounds 3 and 4 (each within the scatter of the next); then compound 1; then compound 2.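

Moving the ring nitrogen, with pyridin-4-yl taking the place of pyridin-3-yl on this saturated ring carbon, gives no change at the digits printed from compound 3 to compound 4 (within the scatter) and so offers the first direct test of where that nitrogen sits: here the two pyridines cannot be told apart. Both pyridines also stand apart from the other aryl groups, with a 2.9-fold lower number from compound 1 to compound 4 (0.46 log units; beyond the scatter) and a 7.3-fold lower number from compound 2 to compound 4 (0.87 log units; beyond the scatter) as the steps for compound 4. Nothing measured here explains this result. Still open, from the compounds shown here alone, is whether pyridin-2-yl, or a pyridine carrying an amine or a methoxy group, would hold this level.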